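Thiophen-2-yl in place of pyridin-3-yl

The compounds below may be only part of what the source reports. "The series", "measured", "known", "first", "only" and "open" are said of these compounds alone.

In an ADME assay on S9 fraction from liver (Rattus norvegicus) for metabolic stability, read by LC-MS, using NADPH, with a stated time of 30 min (a higher number here means that more of the compound is left, a lower number that less of the compound is left), compound 1 `CCCCCCCCc1ccc(OCC(=O)Cn2nnc(C)n2)cc1` gives < 5% as its reading, which is a limit of the assay and not a number. For the measured compounds named here, compound 2 `CCCCCCCCc1ccc(OCC(=O)Cn2nnc(-c3ccccc3Cl)n2)cc1` gives 28% as its reading, and compound 3 `CCCCCCCCc1ccc(OCC(=O)Cn2nnc(-c3cccnc3)n2)cc1` gives 12% as its reading, the lower of the only two true numbers.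

The next compound, compound 4 `CCCCCCCCc1ccc(OCC(=O)Cn2nnc(-c3cccs3)n2)cc1`, carries thiophen-2-yl in place of pyridin-3-yl on an aromatic carbon.

Going by the values given here, three measured steps bear on this change. Swapping methyl for 2-chlorophenyl gave a number at least 23 percentage points higher from compound 1 to compound 2 (beyond the scatter) as the result, and swapping methyl for pyridin-3-yl gave a number at least 7 percentage points higher from compound 1 to compound 3 (that floor lies within the scatter) as the result. Pyridin-3-yl in place of 2-chlorophenyl gave a number 16 percentage points lower from compound 2 to compound 3 (beyond the scatter) as the result, so the ring on this carbon can move the reading. Thiophen-2-yl itself is untested, so only a small rise is expected, from compound 3 at 12% toward compound 2 at 28%, and no step beyond the scatter. The expected change is a number 8 percentage points higher from compound 3 to compound 4 (within the scatter) as an estimate. The estimate for compound 4 is 20%, with an expected range from 8% to 36%.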

Compound 4, percent of the compound remaining: 8%
Estimate against measurement, compound 4: 12 percentage points above; the range from low to high includes it.
By their numbers in this assay, from the lowest: compounds 4 and 3 (each within the scatter of the next); then compound 2. At a limit, below all of these: compound 1.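

In this assay, thiophen-2-yl and pyridin-3-yl on this carbon of the five-membered ring cannot be told apart, with a number 4 percentage points lower from compound 3 to compound 4 (within the scatter), so going from a six-membered to a five-membered aromatic ring with one hetero atom gives no readable step. 2-Chlorophenyl now stands apart from two different rings rather than one, with a number 20 percentage points lower from compound 2 to compound 4 (beyond the scatter), which adds to the earlier gap between compound 2 and compound 3. Against methyl, the data give only a number at least 3 percentage points higher from compound 1 to compound 4 (that floor lies within the scatter) and no firmer step, because one of the two readings is a limit and not a number: the limit of < 5% in this assay, at which 1 of the 4 values shown sits.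

Going by these compounds, it remains open whether the higher reading of compound 2 belongs to its chlorine or to its phenyl ring, a question a plain phenyl group would address. Also open, on these data alone, is how the reading would respond to an amine or a carboxylic acid on this carbon.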